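The source may report more compounds than this note shows. Statements on the series, on what has been measured and on what is new or still open speak of the compounds shown alone.

In an ADME assay on MT4 cells (Homo sapiens) for cytotoxicity, read by spectrophotometry, with a stated time of 5 days (a lower number here means that less compound is tolerated, a higher number that more compound is tolerated), compound 1 (`CCN(CC)CN1C(=O)/C(=N\NC(=S)NO)c2cc(Cl)ccc21`) gives 562000 nM. Compound 2 (`CCN(CC)CN1C(=O)/C(=N\NC(=S)NOC)c2cc(C)ccc21`) gives 573000 nM, which places it level with compound 1, within the scatter of repeated measurements. The next structure, compound 3 (`CCN(CC)CN1C(=O)/C(=N\NC(=S)NO)c2cc(C)ccc21`), is compound 2 with hydrogen in place of methyl on an oxygen, a change from methoxyamino to hydroxyamino (hydrogen in place of methyl on an oxygen). Going by the values given here, no pair of measured compounds shows this change on its own, so the evidence is indirect. Among the compounds with values here, compound 1 already carries the hydroxyamino group and gives 562000 nM, so the numbers so far offer no sign of a shift in either direction. The expected 1.1-fold lower number from compound 2 to compound 3 (0.03 log units; within the scatter) therefore stays within the scatter. Compound 3 is estimated at 530000 nM, with an expected range of 250000 nM to 900000 nM.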

Compound 3, half-maximal cytotoxic concentration: 534000 nM
Estimate against measurement, compound 3: 1.0-fold (0.00 log units) below; measured number inside the range.
By their numbers in this assay, from the lowest: compounds 3, 1 and 2 (each within the scatter of the next).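

In this assay, going by these compounds alone, the change from methoxyamino to hydroxyamino gives a 1.1-fold lower number from compound 2 to compound 3 (0.03 log units; within the scatter) and so provides the first direct reading of hydrogen in place of methyl on this oxygen. Within the data shown here, compound 3 also gives the first direct reading at the aromatic carbon, where methyl in place of chloro gives a 1.1-fold lower number from compound 1 to compound 3 (0.02 log units; within the scatter) and again stays level with its partner. No measurement here explains why either change leaves these values level.

These two steps cover only hydrogen and methyl on the oxygen, and only chloro and methyl on the aromatic carbon. From the compounds shown here alone, whether a longer chain such as butyl on that oxygen, or an amine or a carboxylic acid on that aromatic carbon, would move the number beyond the scatter remains open.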